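Widening the Urea Substituent in a Melanin-Concentrating Hormone Antagonist

A few compounds are considered here, and "the series" means these few. Any claim that something is new, unique, unknown or untested is made for them only; others in the source may bear on it.

Compound 1 `Cc1ccc(CN2CCC(CCN(Cc3ccc(-c4ccc(F)cc4)cc3)C(=O)NC(C)C)CC2)cc1` reaches in an in vitro functional assay on HEK293 cells for antagonist activity at melanin-concentrating hormone receptor 1 (Homo sapiens) (on this read-out higher numbers stand for larger maximal responses and lower numbers for smaller maximal responses), a largest response of 113%, the higher of the two numbers measured. Among the compounds with values here, compound 2 `COc1ccc(-c2ccc(CN(CCC3CCN(Cc4ccc(C)cc4)CC3)C(=O)NC(C)C)cc2)cc1` reaches 91.5% in this assay, and the change a number 21.5 percentage points lower from compound 1 to compound 2 (beyond the scatter) is the only measured step. Compound 3 `CCC(CO)(CO)NC(=O)N(CCC1CCN(Cc2ccc(C)cc2)CC1)Cc1ccc(-c2ccc(F)cc2)cc1` carries a different change: 1,1-bis(hydroxymethyl)propyl in place of isopropyl on an amide-type nitrogen. Within the data shown here, no measured step touches this urea position; the one known step concerns a fluoro on an aromatic carbon, so it gives no guide here. For compound 3 the expected step is a number 13 percentage points lower from compound 1 to compound 3 (beyond the scatter), within the scatter. Compound 3 is estimated in this assay at 100%, ranging from 75% to 120%.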

Compound 3, largest response reached (reported as Imax), in percent of the reference or control that the assay uses: 111%
The estimate for compound 3 lay 11 percentage points below the measured number; the range from low to high includes it.
By their numbers in this assay, from the lowest: compound 2; then compounds 3 and 1 (each within the scatter of the next).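

At the urea position, in this assay, 1,1-bis(hydroxymethyl)propyl in place of isopropyl on an amide-type nitrogen gives a number 2 percentage points lower from compound 1 to compound 3 (within the scatter) and so leaves the response level with that of compound 1. The position thus accepts a substituent of 7 heavy atoms, with 2 hydrogen-bond donors and 2 hydrogen-bond acceptors, in place of one of 3 heavy atoms with neither. No evidence on hand bears on this outcome. From the compounds shown here alone, whether a carboxylic acid or a primary amine on this nitrogen would hold the response at this level remains open. So does whether methoxy in place of fluoro would lower the response in compound 3 as it did in compound 2.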